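Trifluoromethyl in Place of Ethoxycarbonyl: An Expectation

This account rests on a few compounds, and the source may have more. Where it says the series, first, only, none or still open, it means among the compounds named here.

The measured compounds and their values in a functional assay on MCF7 cells (Homo sapiens) for antiproliferative activity, tested at 1 uM; on this read-out lower numbers stand for less inhibition and higher numbers for more inhibition at the one concentration tested (going by the name of the read-out):
compound 1 `CCOC(=O)c1ccc(CO/N=C/c2c(C)nn(C)c2Oc2ccc(Cl)cc2)cc1` gives 33.9%
compound 2 `CCOC(=O)c1ccc(CO/N=C/c2c(C)nn(-c3ccccc3)c2Oc2ccc(Cl)cc2)cc1` gives 12%
compound 3 `COc1cccc(CO/N=C/c2c(C)nn(C)c2Oc2ccccc2)c1` gives 8.4%

Compound 1 holds the highest number of the three in this assay. Its nearest neighbour is compound 2, reached by a number 21.9 percentage points lower from compound 1 to compound 2 (beyond the scatter); the change there is phenyl in place of methyl on an aromatic nitrogen. Compound 3 stands further away, and it differs from compound 1 in more than one place, so only the two values themselves can be compared.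

Compound 4 `Cc1nn(C)c(Oc2ccc(Cl)cc2)c1/C=N/OCc1ccc(C(F)(F)F)cc1` differs from compound 1 as follows: trifluoromethyl in place of ethoxycarbonyl on an aromatic carbon. For the measured compounds named here, no measured step touches this position; the single step from compound 1 to compound 2 concerns the aromatic nitrogen, not the six-membered ring of carbon only. The account therefore rests on compound 1 alone, and a step near the scatter, or a modest fall, is expected, as a number 8.9 percentage points lower from compound 1 to compound 4 (within the scatter). On this basis compound 4 is estimated at 25%, within 8% to 42%.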

Compound 4, a percentage reported as inhibition, at one concentration (the size of the read-out at that concentration, not a potency): 16.4%
Compound 4: middle estimate off by 8.6 percentage points, on the high side; measured number inside the range.
By their numbers in this assay, from the lowest: compounds 3, 2 and 4 (each within the scatter of the next); then compound 1.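

In this assay, for the compounds shown here, the place held by ethoxycarbonyl on the six-membered aromatic ring of carbon only proves sensitive to change: trifluoromethyl in place of ethoxycarbonyl gives a number 17.5 percentage points lower from compound 1 to compound 4 (beyond the scatter) in the first measured step at this position. Together with the step at the aromatic nitrogen, this means that both single changes shown from compound 1 lower the number, so compound 1 keeps the highest value among its direct neighbours. Nothing available explains why this exchange lowers the number.

As far as these compounds go, whether a carboxylic acid, an amide or a nitrile in this place would keep the number of compound 1 remains open. So does whether the same exchange would produce a similar step in a compound carrying phenyl on the aromatic nitrogen.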